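Thiophen-2-yl to pyridin-3-yl: working notes

A few compounds are considered here, and "the series" means these few. Any claim that something is new, unique, unknown or untested is made for them only; others in the source may bear on it.

- compound 1 `Oc1cccc(-c2cc(-c3ccccc3)cc(-c3ccco3)n2)c1`: 9910 nM
- compound 2 `Oc1ccc(-c2cc(-c3ccccc3)cc(-c3ccsc3)n2)cc1`: 3600 nM
- compound 3 `Oc1cccc(-c2cc(-c3ccccc3)nc(-c3cccs3)c2)c1`: 18900 nM

All three values come from a functional assay on HL-60 cells (Homo sapiens) for cytotoxicity, read by ELISA, with a stated time of 2 days; a lower number here means a stronger inhibitor, a higher number a weaker inhibitor. The number for compound 3 lies within the scatter of compound 1 and, beyond the scatter, above that of compound 2. Compound 4 `Oc1cccc(-c2cc(-c3ccccc3)nc(-c3cccnc3)c2)c1` has pyridin-3-yl in place of thiophen-2-yl on an aromatic carbon. Among the measured compounds shown here, no measured pair isolates this change. The measured compounds differ in more than one place, and compound 2 at 3600 nM and compound 3 at 18900 nM mark the span seen so far. No step beyond the scatter is expected in this assay. The estimated step is a 1.4-fold lower number from compound 3 to compound 4 (0.13 log units; within the scatter). For compound 4 the expected value is 14000 nM, with an estimated range of 5000 nM to 40000 nM.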

Compound 4, half-maximal inhibitory concentration: 12600 nM
The estimate for compound 4 lay 1.1-fold (0.05 log units) above the measured number; low and high end bracket the measured number.
By their numbers in this assay, from the lowest: compound 2; then compounds 1, 4 and 3 (each within the scatter of the next).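

In this assay, among the compounds shown here, pyridin-3-yl in place of thiophen-2-yl on the aromatic carbon next to the ring nitrogen gives a 1.5-fold lower number from compound 3 to compound 4 (0.18 log units; within the scatter) as the first step that isolates one change. At this position, the five-membered and six-membered aromatic rings are therefore not separated by this assay in this pair. Nothing measured on these compounds bears on the reason for this result.

Going by these compounds, whether an amine or a carboxylic acid on this carbon would move the number beyond the scatter remains open. Also open, on these data alone, is whether the same ring change would give a similar step with a methoxy group in place of the hydroxyl of the 3-hydroxyphenyl group.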